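The source may report more compounds than this note shows. Statements on the series, on what has been measured and on what is new or still open speak of the compounds shown alone.

Working notes on the series. The shared core of compound 1 `CC(C)(C)Cc1c(-c2ccoc2)sc(N)c1C(=O)c1ccc(Cl)cc1` carries three replacements at the aromatic carbon in question. In an assay on CHO cells for displacement of a labelled ligand from adenosine receptor A1 (Homo sapiens), read by scintillation counting, tested at 10 uM (on this read-out higher numbers stand for more inhibition at the one concentration tested (going by the name of the read-out) and lower numbers for less inhibition), compound 1 gives 1%. Compound 2 `CC(C)(C)Cc1c(-c2ccncc2)sc(N)c1C(=O)c1ccc(Cl)cc1` gives 1% in this assay, and compound 3 `CC(C)(C)Cc1c(/C=C/c2ccc(Cl)cc2)sc(N)c1C(=O)c1ccc(Cl)cc1` gives 1%. Compound 1 therefore stands level with compounds 2 and 3 at the digits shown; compound 2 is its nearest neighbour and compound 3 its furthest, both within the scatter. The measured steps are no change at the digits printed from compound 1 to compound 2 (within the scatter), no change at the digits printed from compound 1 to compound 3 (within the scatter) and no change at the digits printed from compound 2 to compound 3 (within the scatter).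

Compound 4 `Cc1cccc(-c2sc(N)c(C(=O)c3ccc(Cl)cc3)c2CC(C)(C)C)c1` is not yet measured in this assay. It differs from compound 1 as follows: 3-methylphenyl in place of furan-3-yl on an aromatic carbon. All three measured steps at this same aromatic carbon bear on it, and each was flat within the scatter, whether the entering group was a six-membered ring with one nitrogen or a two-carbon chain carrying a chlorinated ring. No step beyond the scatter is therefore expected in this assay for compound 4, so the expected step is a number 1 percentage points higher from compound 1 to compound 4 (within the scatter). The estimate for compound 4 is 2%, with a range from 0% to 12%.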

Compound 4, a percentage reported as inhibition, at one concentration (the size of the read-out at that concentration, not a potency): 1%
Estimate against measurement, compound 4: 1 percentage points above; low and high end bracket the measured number.
By their numbers in this assay, from the lowest: compounds 1, 2, 3 and 4 (each within the scatter of the next).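

Compound 4 places a six-membered aromatic ring of carbon only directly on this carbon next to the ring sulfur, and in this assay the step shows no change at the digits printed from compound 1 to compound 4 (within the scatter). The other two comparisons give the same reading, with no change at the digits printed from compound 2 to compound 4 (within the scatter) and no change at the digits printed from compound 3 to compound 4 (within the scatter), so the flat result at this position now also covers 3-methylphenyl, with its ring of carbon only and 0 hydrogen-bond acceptors. No available evidence accounts for this flat reading.

With all four compounds level, the series does not show whether any group at this carbon can raise the inhibition at the one concentration tested. As far as these compounds go, an aminomethyl group or a carboxylic acid at this carbon remains open, as does a longer chain in place of the neopentyl group.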